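This account rests on a few compounds, and the source may have more. Where it says the series, first, only, none or still open, it means among the compounds named here.

Four compounds tested for antiproliferative activity in a functional assay on MCF7 cells (Homo sapiens) for antiproliferative activity, read by CCK-8 assay, with a stated time of 24 h (a lower number here means a stronger inhibitor, a higher number a weaker inhibitor), are considered here. Compound 1 `C/C(=N\NC(=O)Nc1nc2ccc(CN(C)C)cc2s1)c1ccccn1` carries a pyridin-2-yl group on a carbon with a double bond to nitrogen. In this assay compound 1 reaches only the limit of the assay, > 40000 nM, and no number. Compound 2 `C/C(=N\NC(=O)Nc1nc2ccc(CN(C)C)cc2s1)c1cnccn1` differs from compound 1 by pyrazin-2-yl in place of pyridin-2-yl on a carbon with a double bond to nitrogen. In this assay compound 2 likewise gives only the limit > 40000 nM. The step that the two limits leave unreadable from compound 1 to compound 2 therefore cannot be sized from these two values. Compound 3 `C/C(=N\NC(=O)Nc1ccc(CN2CCC(C)CC2)cc1)c1ccccn1` has a different core from compound 1; the difference between the two cores is not broken down here. In this assay compound 3 also gives only the limit > 40000 nM. All three measured values thus rest at one point, namely (the limit of > 40000 nM in this assay, at which 3 of the 3 values shown sit).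

Compound 4 `C/C(=N\NC(=O)Nc1ccc(CN2CCC(C)CC2)cc1)c1cnccn1` is not yet measured. It differs from compound 3 by pyrazin-2-yl in place of pyridin-2-yl on a carbon with a double bond to nitrogen, which is the same change as that made from compound 1 to compound 2, at a place described in identical words. Because the limit of > 40000 nM in this assay, at which 3 of the 3 values shown sit, holds both compound 1 and compound 2 with nothing readable between them, the step from compound 3 to compound 4 is expected to be a step that the limit leaves unreadable from compound 3 to compound 4 in this assay. On that basis compound 4 is estimated at 60000 nM in this assay, with a range from 30000 nM to 200000 nM, and it is expected most likely to be reported only as a limit, just as compound 3 was.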

Compound 4, half-maximal inhibitory concentration: > 40000 nM
Compound 4: no number, only a limit (the forecaster's own chance of this, stated with the estimate: 85%); the middle value does not contradict the limit.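

Compound 3 and compound 4 both give only a limit in this assay, so no step can be read between them, and the same holds for compound 1 and compound 2: the limit of > 40000 nM in this assay, at which 4 of the 4 values shown sit.

The compounds shown leave open whether pyrazin-2-yl in place of pyridin-2-yl changes antiproliferative activity on either core, and what number any of the four compounds would reach.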